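A Chlorothiophene in Place of Dichlorophenyl on the Hydrazone

The source may hold more compounds than are shown below. What is called first, only, known or untested is meant among the compounds shown, and "the series" means these compounds.

Within the data shown here, compound 3 `Clc1ccc(/C=N/N(Cc2ccccc2)Cc2ccccc2)cc1Cl` stands at the highest of the three numbers known so far in an assay on liver (Sus scrofa) for inhibition of glucose-6-phosphatase catalytic subunit 1 (Homo sapiens), using microsomes (a higher number here means a weaker inhibitor, a lower number a stronger inhibitor), giving 2000 nM. Compound 1 `C(=N/N(Cc1ccccc1)Cc1ccccc1)\c1ccccc1` gives 1500 nM, and the two lie close together, as the step shows: a 1.3-fold higher number from compound 1 to compound 3 (0.12 log units; within the scatter). Compound 2 `COc1ccc(/C=N/N(Cc2ccccc2)Cc2ccccc2)cc1` gives 220 nM, and here the gap is larger: a 9.1-fold higher number from compound 2 to compound 3 (0.96 log units; beyond the scatter). Compound 4 `Clc1ccc(/C=N/N(Cc2ccccc2)Cc2ccccc2)s1` differs from compound 3 at the same place as these two steps: 5-chlorothiophen-2-yl in place of 3,4-dichlorophenyl on a carbon with a double bond to nitrogen. Among the measured compounds shown here, no measured step covers such a swap of a six-membered ring for a five-membered one, so the expectation rests only on the two steps above, one within the scatter and one of modest size. Compound 4 is therefore expected to give 1200 nM in this assay, within a range from 400 nM to 4000 nM. The step that this estimate means is a 1.7-fold lower number from compound 3 to compound 4 (0.22 log units; within the scatter), expected to stay within the scatter rather than to repeat the larger move seen with the methoxy-bearing compound 2.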

Compound 4, half-maximal inhibitory concentration: 170 nM
The estimate for compound 4 lay 7.1-fold (0.85 log units) above the measured number; measured number outside the range, below it.
By their numbers in this assay, from the lowest: compounds 4 and 2 (each within the scatter of the next); then compounds 1 and 3 (each within the scatter of the next).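

The 5-chlorothiophen-2-yl group shows that, on a carbon with a double bond to nitrogen, a five-membered aromatic ring with 1 hetero atom can sit far lower in this assay than the 3,4-dichlorophenyl group (a 12-fold lower number from compound 3 to compound 4 (1.07 log units; beyond the scatter)) or the plain phenyl group (an 8.8-fold lower number from compound 1 to compound 4 (0.95 log units; beyond the scatter)). Compound 3 and compound 4 both carry chlorine, so the presence of chlorine on the ring does not alone set the number here. The remaining step (a 1.3-fold lower number from compound 2 to compound 4 (0.11 log units; within the scatter)) stays within the scatter, so low numbers at this position are not confined to the 4-methoxyphenyl group.

As far as these compounds go, whether a thiophene with an amine or a methoxy group in place of chlorine, or a furan ring, would keep this number remains open. Nothing available accounts for the size of the step from the dichlorophenyl to the chlorothiophene.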